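This account rests on a few compounds, and the source may have more. Where it says the series, first, only, none or still open, it means among the compounds named here.

Working notes on the series. In a functional assay on HL-60 cells (Homo sapiens) for cytotoxicity, read by MTT assay, with a stated time of 24 h (on this read-out lower numbers stand for stronger inhibition and higher numbers for weaker inhibition), compound 1 (`BrCCCOc1c(Br)cc(Br)cc1Oc1ccc(Br)cc1Br`) gives 29.9 ug/mL and compound 2 (`BrCCCCOc1c(Br)cc(Br)cc1Oc1ccc(Br)cc1Br`) gives 25.9 ug/mL on the same read-out. For the measured compounds named here, the only measured step in the set, a 1.2-fold lower number from compound 1 to compound 2 (0.06 log units; within the scatter), concerns the bromo-bearing chain and lies within the scatter. Compound 3 (`Brc1ccc(Oc2cc(Br)cc(Br)c2OCCCCCN2CCN(c3ccccc3)CC2)c(Br)c1`) gives 41.6 ug/mL and so stands within the scatter of both other compounds, which means no order can be read among the three values.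

The next structure is compound 4 (`CC(C)(C)OC(=O)N1CCN(CCCCCOc2c(Br)cc(Br)cc2Oc2ccc(Br)cc2Br)CC1`). The change is tert-butoxycarbonyl in place of phenyl on an amine nitrogen in a ring. Going by the values given here, no measured step touches this place, so the data hold no direct precedent for it. The step from compound 1 to compound 2 bears on it only weakly, as a sign that one change elsewhere in the series moved the number by less than the scatter. All three values in this assay also sit close together. The step expected here is a 1.2-fold lower number from compound 3 to compound 4 (0.08 log units; within the scatter) and it stays within the scatter, so no direction is claimed. For compound 4 the estimated value is 35 ug/mL (expected range 18 ug/mL to 70 ug/mL).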

Compound 4, half-maximal inhibitory concentration: 32.1 ug/mL
Beside the measured number, compound 4's estimate is 1.1-fold (0.04 log units) above it; the range from low to high includes it.
By their numbers in this assay, from the lowest: compounds 2, 1, 4 and 3 (each within the scatter of the next).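

In this assay, for the compounds shown here, the exchange of phenyl for tert-butoxycarbonyl on an amine nitrogen in a ring gives a 1.3-fold lower number from compound 3 to compound 4 (0.11 log units; within the scatter), the first measured step at this place. The exchange swaps a six-membered aromatic ring of carbon only, with 0 hydrogen-bond acceptors, for a group with no ring, 1 double bond outside aromatic rings and 2 hydrogen-bond acceptors, yet compound 3 and compound 4 cannot be told apart on this read-out. The data offer no measured property that bears on this result, so it remains an observation without an explanation.

On these data alone, it remains open whether any other group on this nitrogen, such as benzyl, acetyl or a plain hydrogen leaving a secondary amine, would give a step beyond the scatter. As far as these compounds go, it is equally open whether a longer chain on the shared core, carrying either phenyl or tert-butoxycarbonyl at this place, would separate the values in this assay.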